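Working notes: tolerated concentration, compounds 1 to 4

The compounds below may be only part of what the source reports. "The series", "measured", "known", "first", "only" and "open" are said of these compounds alone.

Measured so far in an ADME assay on HEL cells (Homo sapiens), read by cell counting, with a stated time of 3 days; a higher number here means that more compound is tolerated, a lower number that less compound is tolerated:
compound 1 `CCCCCCc1ccc(C#CC#Cc2cn([C@H]3C[C@H](O)[C@@H](CO)O3)c(=O)[nH]c2=O)cc1`: 35000 nM
compound 2 `O=c1[nH]c(=O)n([C@H]2C[C@H](O)[C@@H](CO)O2)cc1C#CC#Cc1ccccn1`: 1500 nM
compound 3 `O=c1[nH]c(=O)n([C@H]2C[C@H](O)[C@@H](CO)O2)cc1C#CC#Cc1ccc([N+](=O)[O-])cc1`: 89000 nM

Compound 3 stands highest of the three in this assay, with compound 1 nearest at a 2.5-fold higher number from compound 1 to compound 3 (0.41 log units; beyond the scatter) and compound 2 furthest at a 59-fold higher number from compound 2 to compound 3 (1.77 log units; beyond the scatter).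

Compound 4 `O=c1[nH]c(=O)n([C@H]2C[C@H](O)[C@@H](CO)O2)cc1C#CC#CC1CC1` is not yet measured. It differs from compound 3 by cyclopropyl in place of 4-nitrophenyl on a triple-bonded carbon. Both measured steps change the group on the triple-bonded carbon, so both bear on this one: the swap of a ring for a ring was large, the swap of a substituent on the ring was modest. A cyclopropyl is a ring change, so a step beyond the scatter toward a lower number is expected in this assay, estimated as a 2.5-fold lower number from compound 3 to compound 4 (0.41 log units; beyond the scatter). Compound 4 is therefore expected at 35000 nM, within 8000 nM to 150000 nM.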

Compound 4, half-maximal cytotoxic concentration: > 100000 nM
Compound 4 ended at the assay's limit; the forecaster's own chance of this, stated with the estimate: 20%; middle value at least 2.8-fold (0.45 log units) from the limit.
By their numbers in this assay, from the lowest: compound 2; then compound 1; then compound 3. At a limit, above all of these: compound 4.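

In this assay compound 4 reads as a limit of the assay and not as a number: the limit of > 100000 nM in this assay, at which 1 of the 4 values shown sits.
The large step of an at least 66-fold higher number from compound 2 to compound 4 (1.82 log units; beyond the scatter) shows that replacing pyridin-2-yl with a ring does not by itself bring a low number, and that a non-aromatic cyclopropyl can stand on this triple-bonded carbon. The floor of an at least 1.1-fold higher number from compound 3 to compound 4 (0.05 log units; that floor lies within the scatter) lies within the scatter and so does not order the two compounds.

Going by these compounds, how far compound 4 lies past the limit stays open. So does the outcome with an amine, a carboxylic acid or a longer alkyl chain at this place.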